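This account rests on a few compounds, and the source may have more. Where it says the series, first, only, none or still open, it means among the compounds named here.

Measured in a functional assay on MCF7 cells (Homo sapiens) for antiproliferative activity; on this read-out higher numbers stand for weaker inhibition of growth and lower numbers for stronger inhibition of growth:
- compound 1 `CC/C=C\[C@H](C)[C@H](OC(N)=O)[C@@H](C)[C@H](O)[C@@H](C)C/C(C)=C\[C@H](C)[C@@H](O)[C@@H](C)/C=C\[C@@H](O)C[C@H](O)[C@H](C)CO`: 1000 nM
- compound 2 `CC/C=C\[C@H](C)[C@H](OC(N)=O)[C@@H](C)[C@H](O)[C@@H](C)C/C(C)=C\[C@H](C)[C@@H](O)[C@@H](C)/C=C\[C@@H](O)C[C@H]1CCC(=O)O1`: 6.4 nM

Among the measured compounds shown here, compound 1 has the higher of the two numbers, and compound 2 is its only neighbour. The next compound, compound 3 `CC/C=C\[C@H](C)[C@H](OC(N)=O)[C@@H](C)[C@H](O)[C@@H](C)C/C(C)=C\[C@H](C)[C@@H](O)[C@@H](C)/C=C\[C@@H](O)C[C@@H]1OC(=O)NC[C@H]1C`, has not yet been measured. It differs from compound 1 as follows: a group of 8 heavy atoms (5 carbon, 1 nitrogen, 2 oxygen; one six-membered non-aromatic ring with 2 hetero atoms) in place of a group of 6 heavy atoms (4 carbon, 2 oxygen; no ring), on a saturated chain carbon, two bonds along the chain from a double-bonded chain carbon and an oxygen on a saturated carbon. In words, a group of 8 heavy atoms with one six-membered non-aromatic ring with 2 hetero atoms replaces the open group of 6 heavy atoms, on a saturated chain carbon.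

For the measured compounds named here, only one measured step bears on this change: a 160-fold lower number from compound 1 to compound 2 (2.19 log units; beyond the scatter). That step is large and beyond the scatter, and it also puts a ring in place of the same open group at the same place. The ring in compound 2 is a different one, though, so the step is only a rough guide. A large move to a lower number in this assay is therefore expected, probably somewhat smaller than that step. The expected change is a 25-fold lower number from compound 1 to compound 3 (1.40 log units; beyond the scatter). For compound 3 the estimated value is 40 nM, with an expected range of 8 nM to 200 nM.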

Compound 3, concentration for 50% growth inhibition: 110 nM
For compound 3 the middle estimate is 2.8-fold (0.44 log units) below the measured one; measured number inside the range.
By their numbers in this assay, from the lowest: compound 2; then compound 3; then compound 1.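

In this assay, a second ring at this saturated chain carbon also gives a lower number than the open group, with a 9.1-fold lower number from compound 1 to compound 3 (0.96 log units; beyond the scatter), so this direction of change is not confined to the ring in compound 2. The identity of the ring also matters: replacing the five-membered non-aromatic ring with 1 hetero atom by the group of 8 heavy atoms with its six-membered non-aromatic ring with 2 hetero atoms gives a 17-fold higher number from compound 2 to compound 3 (1.24 log units; beyond the scatter), and compound 3 therefore falls between the other two compounds. No evidence is available on what lies behind this gap between the two rings.

The compounds shown leave open which feature of the entering group sets it apart from the ring in compound 2, as the two rings differ at once in ring size, in hetero atoms and in heavy-atom count. They also leave open how an amine, a carboxylic acid or a longer chain at this place would compare in this assay.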